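Chloro in place of trifluoromethyl: notes on compound 4

A few compounds are considered here, and "the series" means these few. Any claim that something is new, unique, unknown or untested is made for them only; others in the source may bear on it.

Compound 1 `CCOC(=O)N1C(=S)N=C(C)/C(=C(/O)OCC)C1c1cccc([N+](=O)[O-])c1`: 17 nM
Compound 2 `CCO/C(O)=C1\C(C)=NC(=S)N(C(=O)O[C@H]2CCN(Cc3ccccc3)C2)C1c1ccccc1C(F)(F)F`: 2 nM
Compound 3 `CC1=NC(=S)N(C(=O)OC2CCN(Cc3ccccc3)CC2)C(c2ccccc2C(F)(F)F)/C1=C(\O)OC(C)C`: 5 nM

All three values come from a functional assay (aorta) for inhibition, with Oryctolagus cuniculus as the target; on this read-out higher numbers stand for weaker inhibition and lower numbers for stronger inhibition. Compound 3 stands second highest of the three, at 5 nM. Its number lies above that of compound 2 and below that of compound 1, and both gaps are beyond the scatter.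

The next entry is compound 4 `CC1=NC(=S)N(C(=O)OC2CCN(Cc3ccccc3)CC2)C(c2ccccc2Cl)/C1=C(\O)OC(C)C`, which keeps everything in compound 3 except one group: chloro in place of trifluoromethyl on an aromatic carbon, so that 2-(trifluoromethyl)phenyl becomes 2-chlorophenyl (chloro in place of trifluoromethyl on an aromatic carbon). Going by the values given here, no measured pair isolates this change. Among the compounds with values here, compound 2 and compound 3 share the 2-(trifluoromethyl)phenyl group but differ elsewhere, and no measured compound yet carries 2-chlorophenyl. Within the data shown here, the expectation therefore has no direct precedent and is anchored on compound 3 at 5 nM, with no direction favoured and no shift beyond the scatter assumed in this assay. The estimated step is a 1.2-fold higher number from compound 3 to compound 4 (0.08 log units; within the scatter), and it is expected to stay within the scatter. Among the measured compounds shown here, the range is kept wide, as no measurement yet bears on this replacement. For compound 4 the expected value is 6 nM, with an estimated range from 2 nM to 18 nM.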

Compound 4, half-maximal inhibitory concentration: 5 nM
Estimate against measurement, compound 4: 1.2-fold (0.08 log units) above; low and high end bracket the measured number.
By their numbers in this assay, from the lowest: compound 2; then compounds 3 and 4 (each within the scatter of the next); then compound 1.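

Trifluoromethyl giving way to chloro on an aromatic carbon ortho to a large group shows no change at the digits printed from compound 3 to compound 4 (within the scatter) in this assay and this is the only pair in the series that isolates the replacement. The read-out does not separate 2-(trifluoromethyl)phenyl from 2-chlorophenyl on this background, even though the entering group has one heavy atom against four for the group that leaves, so for this pair the full trifluoromethyl group is not required to keep the number where it stands. No measurement at hand accounts for the two groups reading alike.

Open, going by these compounds, is how far this position accepts other groups, since only these two substituents are compared here: a methoxy group, a nitrile or plain hydrogen in the same place would show whether the result extends beyond trifluoromethyl and chloro. Also open, on these data alone, is whether the same replacement reads alike on the background of compound 2, as one pair on one background cannot settle that.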